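Losing the Second Ring: From Compound 3 to Compound 4

This account rests on a few compounds, and the source may have more. Where it says the series, first, only, none or still open, it means among the compounds named here.

Compound 1 `COc1ccccc1-c1cccc(S(=O)(=O)N2CCC(N3CCC(C)CC3)CC2)c1`: 21 nM
Compound 2 `COc1ccc(-c2cccc(S(=O)(=O)N3CCC(N4CCC(C)CC4)CC3)c2)cc1`: 23 nM
Compound 3 `CC1CCN(C2CCN(S(=O)(=O)c3cccc(-c4ccccc4)c3)CC2)CC1`: 2 nM

All three were tested in a functional assay on DLD-1 cells (Homo sapiens) for antiproliferative activity, read by CellTiter-Glo, with a stated time of 72 h; a higher number here means a weaker inhibitor, a lower number a stronger inhibitor. Compound 3 stands lowest of the three numbers: the step of an 11-fold lower number from compound 1 to compound 3 (1.02 log units; beyond the scatter) and the step of a 12-fold lower number from compound 2 to compound 3 (1.06 log units; beyond the scatter) both lie beyond the scatter, while a 1.1-fold higher number from compound 1 to compound 2 (0.04 log units; within the scatter) lies within it. So removing the methoxy from the phenyl, whichever position it sat on, gave a clearly stronger inhibitor.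

Compound 4 `CC1CCN(C2CCN(S(=O)(=O)c3cccc(N)c3)CC2)CC1` has not yet been measured. Its difference from compound 3 is amino in place of phenyl on an aromatic carbon. Among the measured compounds shown here, no measured step removes the phenyl itself, so nothing directly shows the direction of this change. The two steps that touch this part of the molecule, an 11-fold lower number from compound 1 to compound 3 (1.02 log units; beyond the scatter) and a 12-fold lower number from compound 2 to compound 3 (1.06 log units; beyond the scatter), show that even a small change on that phenyl moved the number a great deal; taking away the whole ring and placing an amino there is a larger change than either. The expectation is therefore a step beyond the scatter, most likely toward a higher number, with wide uncertainty. Compound 4 is expected to give 200 nM in this assay, within a range from 30 nM to 1500 nM, which means an expected step of a 100-fold higher number from compound 3 to compound 4 (2.00 log units; beyond the scatter).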

Compound 4, half-maximal inhibitory concentration: 3400 nM
Beside the measured number, compound 4's estimate is 17-fold (1.23 log units) below it; measured number outside the range, above it.
By their numbers in this assay, from the lowest: compound 3; then compounds 1 and 2 (each within the scatter of the next); then compound 4.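

The earlier compounds shown here changed only a methoxy on the phenyl, so the ring itself was always there; here it is gone, and in this assay the step (a 1700-fold higher number from compound 3 to compound 4 (3.23 log units; beyond the scatter)) is far larger than the one seen on removing a methoxy (an 11-fold lower number from compound 1 to compound 3 (1.02 log units; beyond the scatter)). The two methoxyphenyl compounds, although they give higher numbers than compound 3, also stand well clear of the amino compound (a 160-fold higher number from compound 1 to compound 4 (2.21 log units; beyond the scatter) and a 150-fold higher number from compound 2 to compound 4 (2.17 log units; beyond the scatter)). Across these four compounds, then, replacing the whole ring with amino matters much more than whether the ring carries a methoxy.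

This single swap takes away the phenyl and brings in the amino at the same time, so these compounds cannot separate the two changes, and a plain hydrogen, a methyl, a cyclohexyl ring or a pyridine ring on this aromatic carbon would be needed to tell them apart. No measurement shown here explains why the number rises so steeply.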